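Replacing a branched amine with piperidine on the trifluoromethyl core

The source may hold more compounds than are shown below. What is called first, only, known or untested is meant among the compounds shown, and "the series" means these compounds.

Measured compounds:
compound 1 `CCCN(Cc1ccccc1)C(=O)c1c(C)nc2n1CCCN2c1c(C)cc(C)cc1C` > 5000 nM
compound 2 `CCCN(CC1CC1)C(=O)c1c(C)nc2n1CCCN2c1c(C)cc(C)cc1C` > 5000 nM
compound 3 `CCCN(Cc1c(C(F)(F)F)nc2n1CCCN2c1c(C)cc(C)cc1C)CC1CCC1` 21 nM

In an in vitro assay on IMR-32 cells for displacement of a labelled ligand from corticotropin-releasing factor receptor 1 (Homo sapiens) (on this read-out lower numbers stand for stronger inhibition and higher numbers for weaker inhibition), compound 1 gives only a limit, > 5000 nM. Compound 2 likewise gives only a limit, > 5000 nM, so a step that the two limits leave unreadable from compound 1 to compound 2. For the measured compounds named here, compound 3 is the only compound with a number, 21 nM, the other two values sitting at the limit of > 5000 nM in this assay, at which 2 of the 3 values shown sit.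

Compound 4 `Cc1cc(C)c(N2CCCn3c2nc(C(F)(F)F)c3CN2CCCCC2)c(C)c1` differs from compound 3 by piperidin-1-yl in place of (cyclobutylmethyl)(propyl)amino on a saturated chain carbon bound to an aromatic carbon. No measured step touches this position, and the one measured step is unreadable, so nothing shown gives the size of this change. Compound 4 is therefore expected to remain in the same region as compound 3, with a modest loss allowed, estimated at 80 nM (range 15 nM to 600 nM), a step of a 3.8-fold higher number from compound 3 to compound 4 (0.58 log units; beyond the scatter).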

Compound 4, inhibition constant: 245 nM
Compound 4: middle estimate off by 3.1-fold (0.49 log units), on the low side, and the stated range covers the measured number.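

In this assay, the amine on a saturated chain carbon bound to an aromatic carbon proves sensitive: piperidin-1-yl in place of (cyclobutylmethyl)(propyl)amino gives a 12-fold higher number from compound 3 to compound 4 (1.07 log units; beyond the scatter). Compound 4 nevertheless keeps a measured number rather than a limit, so this change weakens the read-out without abolishing it. Nothing shown gives a cause for this loss.

The compounds shown leave open whether the loss follows from closing the ring or from the shorter substituent. A dipropylamino or an azepan-1-yl group at this place would help separate the two.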